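Sulfonyl aryl exchange on compound 2: working notes

The compounds below may be only part of what the source reports. "The series", "measured", "known", "first", "only" and "open" are said of these compounds alone.

In a functional assay on HL-60 cells (Homo sapiens) for inhibition, read by CCK-8 assay, with a stated time of 48 h, tested at 20 uM (on this read-out lower numbers stand for less inhibition of growth and higher numbers for more inhibition of growth at the one concentration tested), compound 1 (`N#C/C(=C\c1ccccc1OS(=O)(=O)c1ccc(F)cc1)C(=O)Nc1nnc(Cc2cccc(F)c2)s1`) gives 22% and compound 2 (`N#C/C(=C\c1ccccc1OS(=O)(=O)c1ccccc1[N+](=O)[O-])C(=O)Nc1nnc(Cc2ccc(Cl)cc2)s1`) gives 19%. These two values lie within the scatter of each other, so compound 2 stands level with compound 1. Going by the values given here, the two structures differ in more than one place, and no measured pair shows a single change.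

The next compound is compound 3 (`N#C/C(=C\c1ccccc1OS(=O)(=O)c1ccc(F)cc1)C(=O)Nc1nnc(Cc2ccc(Cl)cc2)s1`), which has 4-fluorophenyl in place of 2-nitrophenyl on a sulfonyl sulfur. The same (4-fluorophenyl)sulfonyl is already present in compound 1, which gives 22%. The rest of compound 3 is unchanged from compound 2, which gives 19%.

The data do not isolate this exchange, and the two measured values give no reason to expect a move in either direction in this assay. The expected step of a number 2 percentage points higher from compound 2 to compound 3 (within the scatter) stays within the scatter. The estimate for compound 3 is 21%, with an expected range of 8% to 36%.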

Compound 3, percent growth inhibition at one concentration: 20%
Beside the measured number, compound 3's estimate is 1 percentage points above it; the range from low to high includes it.
By their numbers in this assay, from the lowest: compounds 2, 3 and 1 (each within the scatter of the next).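

In this assay, the exchange of 2-nitrophenyl for 4-fluorophenyl on the sulfonyl sulfur can now be read alone (the step is a number 1 percentage points higher from compound 2 to compound 3 (within the scatter)), so with the rest of the structure held fixed, these two aryl groups cannot be told apart at this position. Compound 3 also isolates a second single change, 4-chlorophenyl in place of 3-fluorophenyl on a saturated chain carbon bound to an aromatic carbon (the step is a number 2 percentage points lower from compound 1 to compound 3 (within the scatter)), and this exchange likewise stays within the scatter with the (4-fluorophenyl)sulfonyl held fixed. No measurement on hand offers a cause for either step.

The compounds shown leave open whether a sulfonyl substituent of another kind, such as a methyl group or a phenyl ring bearing an amine or a carboxylic acid, would separate from these aryl groups. From the compounds shown here alone, it also remains open whether either exchange would give the same result on a different partner group, since each has been read only once, and whether any single change to this series gives a step beyond the scatter.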